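The source may hold more compounds than are shown below. What is called first, only, known or untested is meant among the compounds shown, and "the series" means these compounds.

For the measured compounds named here, in a functional assay on MDA-MB-435 cells (Homo sapiens) for inhibition, read by sulforhodamine B assay, with a stated time of 48 h (a lower number here means a stronger inhibitor, a higher number a weaker inhibitor), compound 2 `COc1ccc(N(C)c2nc(C)nc3c2CCC3)cc1` gives 7 nM, the lowest of the three numbers so far. Compound 3 `COc1ccc(N(C)c2nc(C)nc3c2C(C)CC3)cc1` gives 18.8 nM, and compound 1 `C=CC1Cc2nc(C)nc(N(C)c3ccc(OC)cc3)c2C1` gives 73.2 nM. Next is compound 4 `Cc1ccc(N(C)c2nc(C)nc3c2CCC3)cc1`, with methyl in place of methoxy on an aromatic carbon, para to a large group: methyl in place of methoxy on an aromatic carbon. Neither measured step touches that carbon. Both fall on a saturated ring carbon: a 2.7-fold higher number from compound 2 to compound 3 (0.43 log units; beyond the scatter) is modest and a 10-fold lower number from compound 1 to compound 2 (1.02 log units; beyond the scatter) is large. They indicate only how far one change has moved this assay, and both other compounds stand higher than compound 2. The expected change is upward, of a size between those two: a 5.7-fold higher number from compound 2 to compound 4 (0.76 log units; beyond the scatter). For compound 4 the estimated value is 40 nM, within 10 nM to 200 nM.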

Compound 4, half-maximal inhibitory concentration: 360 nM
For compound 4 the middle estimate is 9.0-fold (0.95 log units) below the measured one, and the stated range ends below it.
By their numbers in this assay, from the lowest: compound 2; then compound 3; then compound 1; then compound 4.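

For the compounds shown here, the aromatic carbon para to a large group carries far more weight than the earlier steps could show: methyl in place of methoxy in this assay gives a 51-fold higher number from compound 2 to compound 4 (1.71 log units; beyond the scatter), the largest step printed so far and one that outruns both steps on a saturated ring carbon. The change removes the hydrogen-bond acceptor counted in methoxy, but no measurement here ties the step to any cause. The compounds shown leave open how ethoxy, a hydroxyl or an amine at this carbon would read. Also open, from the compounds shown here alone, is whether the step would hold alongside the vinyl or methyl on the saturated ring carbon.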